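Bromine on the Fused Ring: Two Cores Compared

This account rests on a few compounds, and the source may have more. Where it says the series, first, only, none or still open, it means among the compounds named here.

Measured compounds:
compound 1 `O=C1N=C(N2N=C(c3ccccc3)CC2c2ccccc2O)S/C1=C1/C(=O)Nc2ccccc21` 4400 nM
compound 2 `O=C1N=C(N2N=C(c3ccccc3)CC2c2ccccc2O)S/C1=C1/C(=O)Nc2ccc(Br)cc21` 660 nM
compound 3 `COc1ccc(C2=NN(C3=NC(=O)/C(=C4\C(=O)Nc5ccccc54)S3)C(c3ccc(Cl)cc3)C2)cc1` 100000 nM

Compound 1 and compound 2 share a core and differ in one place: bromo in place of hydrogen on an aromatic carbon. In a functional assay on cells (Melanoma cell, Homo sapiens) for cytotoxicity, read by sulforhodamine B assay, with a stated time of 48 h (on this read-out higher numbers stand for weaker inhibition of growth and lower numbers for stronger inhibition of growth), compound 1 gives 4400 nM, and compound 2 gives 660 nM. The step between them is a 6.7-fold lower number from compound 1 to compound 2 (0.82 log units; beyond the scatter).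

Compound 3 rests on a different core. The difference between the two cores is not broken down here. In this assay compound 3 gives 100000 nM, the highest of the three numbers, and a far larger number than either compound 1 or compound 2.

Compound 4 `COc1ccc(C2=NN(C3=NC(=O)/C(=C4\C(=O)Nc5ccc(Br)cc54)S3)C(c3ccc(Cl)cc3)C2)cc1` has not yet been measured. It relates to compound 3 as compound 2 relates to compound 1: bromo in place of hydrogen on an aromatic carbon. The place of the entering bromo is described in the same words for both pairs, so this is the same change on a different core. Whether the second core answers to it as the first did is not shown by anything here; the only guide is the single measured step, and the cores differ in a way that is not resolved. Compound 4 is therefore expected to lie lower than compound 3 by about a 5.0-fold lower number from compound 3 to compound 4 (0.70 log units; beyond the scatter), a step set against the measured one from compound 1 to compound 2, but with wide uncertainty. The uncertainty is wide because compound 3 starts from the high value 100000 nM. The estimate for compound 4 in this assay is 20000 nM, with a range from 5000 nM to 100000 nM.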

Compound 4, concentration for total growth inhibition: 340 nM
The estimate for compound 4 lay 59-fold (1.77 log units) above the measured number; measured number below the stated range.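

In this assay, bromo in place of hydrogen on an aromatic carbon again gives a lower number on the second core, with a 290-fold lower number from compound 3 to compound 4 (2.47 log units; beyond the scatter), so the direction of the step seen on the core of compound 1 also holds on the core of compound 3. The size of the step did not carry over, and the two cores answered to the same change to clearly different degrees: the same change on two cores in this assay, a 6.7-fold lower number (0.82 log units; beyond the scatter) from compound 1 to compound 2 and a 290-fold lower number (2.47 log units; beyond the scatter) from compound 3 to compound 4, 44-fold (1.64 log units) apart, beyond the scatter of two such steps. These two pairs show that the direction was shared here and that a step measured on one core was a poor guide to its size on the other, but they do not show what sets the size of the step or how the change would behave on any further core.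

The compounds shown leave open whether fluoro, a nitrile or an amine in place of the bromo, on an aromatic carbon of the same ring, would also give a lower number on both cores, and whether those steps would differ in size as the bromo steps do. Equally open, going by these compounds, is which of the groups that separate the two cores, taken singly, goes with the larger step.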